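Arylidene variation on the shared core: compound 3 to compound 4

The source may report more compounds than this note shows. Statements on the series, on what has been measured and on what is new or still open speak of the compounds shown alone.

The series keeps the shared core of compound 1 `C=CCn1c(=O)/c(=C\c2cccc(F)c2)[nH]c(=O)/c1=C\c1ccccc1OC` and varies the aryl group on a double-bonded chain carbon bound to an aromatic carbon. In a functional assay on MOLT-4 cells (Homo sapiens) for cytotoxicity, read by CCK-8 assay, with a stated time of 72 h (a higher number here means a weaker inhibitor, a lower number a stronger inhibitor), compound 1 gives 6500 nM. Compound 2 `C=CCn1c(=O)/c(=C\c2ccccc2C(F)(F)F)[nH]c(=O)/c1=C\c1ccccc1OC` carries 2-(trifluoromethyl)phenyl at that position, and in this assay compound 2 gives 4400 nM; the step of a 1.5-fold lower number from compound 1 to compound 2 (0.17 log units; within the scatter) is within the scatter. Compound 3 `C=CCn1c(=O)/c(=C\c2ccc(C)cc2)[nH]c(=O)/c1=C\c1ccccc1OC` carries 4-methylphenyl, and in this assay compound 3 is reported as "not active" (no number reported), so no number stands for it. Compound 4 `C=CCn1c(=O)/c(=C\c2cc(F)ccc2C)[nH]c(=O)/c1=C\c1ccccc1OC` differs from compound 3 by 5-fluoro-2-methylphenyl in place of 4-methylphenyl on a double-bonded chain carbon bound to an aromatic carbon. Among the compounds with values here, no measured step starts from 4-methylphenyl or ends at 5-fluoro-2-methylphenyl; the single measured step, between compound 1 and compound 2, concerns other groups and is within the scatter, so it gives no direction for this change. What the numbers show is that the phenyl groups of compound 1 and compound 2 returned micromolar-range values while compound 3 returned none. Compound 4 is therefore expected to give in this assay roughly 8000 nM, within 2500 nM to 30000 nM, with a real chance that again no number results.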

Compound 4, half-maximal inhibitory concentration: 3800 nM
Compound 4: middle estimate off by 2.1-fold (0.32 log units), on the high side; the range from low to high includes it.
By their numbers in this assay, from the lowest: compounds 4, 2 and 1 (each within the scatter of the next).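

In this assay, methyl in place of hydrogen on an aromatic carbon gives a 1.7-fold lower number from compound 1 to compound 4 (0.23 log units; within the scatter) and 5-fluoro-2-methylphenyl in place of 2-(trifluoromethyl)phenyl gives a 1.2-fold lower number from compound 2 to compound 4 (0.06 log units; within the scatter) so the three aryl groups with numbers show no order at this position. Within the data shown here, compound 3 has no number, so the change from 4-methylphenyl to 5-fluoro-2-methylphenyl cannot be read as a step; compound 4 shows only that a phenyl group carrying methyl can return a value here, which compound 3 alone did not suggest. No measurement at hand explains the contrast between compound 3 and compound 4.

Still open, going by these compounds, is whether the fluorine or the shifted methyl separates compound 4 from compound 3. Also open, on these data alone, is whether an amine or a carboxylic acid on the phenyl group would move the number beyond the scatter.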